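Trifluoromethylphenyl in Place of Difluorophenyl: an Expected Shift

This account rests on a few compounds, and the source may have more. Where it says the series, first, only, none or still open, it means among the compounds named here.

Of the compounds shown here, three sharing one core have been measured in a functional assay on MKN-45 cells (Homo sapiens) for antiproliferative activity, with a stated time of 72 h; on this read-out lower numbers stand for stronger inhibition and higher numbers for weaker inhibition. Compound 1 `Cn1cc(-c2ccc(NC(=O)c3cn(CC4CCOCC4)cc(-c4ccc(F)cc4)c3=O)cc2F)c2c(N)ncnc21` gives 93.7 nM, and compound 3 `Cn1cc(-c2ccc(NC(=O)c3cn(CC4CCOCC4)cc(-c4ccc(F)cc4)c3=O)c(F)c2)c2c(N)ncnc21` gives 210 nM. Compound 2 `Cn1cc(-c2ccc(NC(=O)c3cn(CC4CCOCC4)cc(-c4ccc(F)cc4F)c3=O)cc2)c2c(N)ncnc21` gives 501 nM, the highest number of the three: its nearest neighbour is compound 3, a gap that lies beyond the usual scatter, and the gap to compound 1 is wider still. Compound 4 `Cn1cc(-c2ccc(NC(=O)c3cn(CC4CCOCC4)cc(-c4ccc(C(F)(F)F)cc4)c3=O)cc2)c2c(N)ncnc21` has not yet been measured. It differs from compound 2 in one place: 4-(trifluoromethyl)phenyl in place of 2,4-difluorophenyl on an aromatic carbon. Going by the values given here, no pair of measured compounds shows this particular exchange, so its effect cannot be read from the data and can only be estimated. Because compound 2 sits at 501 nM, the highest number measured, a modest move toward lower numbers is expected, though it may not clear the scatter. The expected step of a 1.8-fold lower number from compound 2 to compound 4 (0.25 log units; within the scatter) is small. Compound 4 is expected to give 280 nM, within a range from 90 nM to 900 nM.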

Compound 4, half-maximal inhibitory concentration: 826 nM
Compound 4: the middle estimate sits 3.0-fold (0.47 log units) below what was measured; the range from low to high includes it.
By their numbers in this assay, from the lowest: compound 1; then compound 3; then compounds 2 and 4 (each within the scatter of the next).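

In this assay, going by these compounds alone, 4-(trifluoromethyl)phenyl in place of 2,4-difluorophenyl gives a 1.6-fold higher number from compound 2 to compound 4 (0.22 log units; within the scatter), the first exchange at this aromatic carbon that can be read directly. This exchange therefore leaves the two compounds indistinguishable on this read-out, so this pair gives no sign that the position separates these two groups. Nothing measured on either group bears on this result.

Compounds 1 and 3 each differ from compound 4 in more than one place, so they add no further reading of this exchange. As far as these compounds go, it remains open whether a very different group in this place, such as an amine or a carboxylic acid on the phenyl ring, would shift the number beyond the usual scatter.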